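The compounds below may be only part of what the source reports. "The series", "measured", "known", "first", "only" and "open" are said of these compounds alone.

Working notes on the series. Among the measured compounds shown here, compound 1 `COc1ccc2nc(C)cc(OCC(=O)Nc3cc(C)cc(C)c3)c2c1` is the only member with a number in a toxicity assay on HepG2 cells (Homo sapiens) for inhibition, read by CellTiter-Glo, with a stated time of 48 h (a lower number here means a stronger inhibitor, a higher number a weaker inhibitor), where compound 1 gives 20000 nM. Compound 2 `CCOc1ccc2nc(C)cc(OCC(=O)Nc3cc(C)cc(C)c3)c2c1` sits at a limit of this assay, > 100000 nM, and not at a number. For the measured compounds named here, the one measured step, an at least 5.0-fold higher number from compound 1 to compound 2 (0.69 log units; beyond the scatter), therefore rests on the limit of > 100000 nM in this assay, at which 1 of the 2 values shown sits, and concerns the saturated chain carbon bound to an oxygen on the aromatic ring, a place untouched by the change to compound 3 `COc1ccc2nc(C)cc(OCC(=O)Nc3c(C)cccc3C)c2c1`. Compound 3 differs from compound 1 by 2,6-dimethylphenyl in place of 3,5-dimethylphenyl on an amide-type nitrogen. Going by the values given here, no measured step touches the amide-type nitrogen, so nothing here tells the size or direction of the step to compound 3 in this assay. The working expectation for compound 3 is a step within the scatter, a 1.3-fold higher number from compound 1 to compound 3 (0.10 log units; within the scatter), with a wide range to cover the unknown. Compound 3 is estimated at 25000 nM, between 8000 nM and 100000 nM.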

Compound 3, half-maximal inhibitory concentration: > 100000 nM
Compound 3: only a limit was reported; the forecaster's own chance of this, stated with the estimate: 30%; middle value at least 4.0-fold (0.60 log units) from the limit.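

Exchanging 3,5-dimethylphenyl for 2,6-dimethylphenyl on the amide-type nitrogen gives an at least 5.0-fold higher number from compound 1 to compound 3 (0.69 log units; beyond the scatter) in this assay, so this position responds to where the two methyl groups stand on the ring, even though the group keeps the same heavy atoms. In this assay compound 3 gives > 100000 nM, which is a limit and not a number. The size of the step is therefore only a lower bound, and a change at the amide-type nitrogen now ends at the same limit as the earlier change on the saturated chain carbon: the limit of > 100000 nM in this assay, at which 2 of the 3 values shown sit.

As far as these compounds go, how far compound 3 lies past that limit remains open. Also open, from the compounds shown here alone, is whether an unsubstituted phenyl, a phenyl with a single methyl or a chlorophenyl on the amide-type nitrogen would stay near compound 1 or also reach the limit.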